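A few compounds are considered here, and "the series" means these few. Any claim that something is new, unique, unknown or untested is made for them only; others in the source may bear on it.

Measured compounds:
- compound 1, `CCCNC(=C\C(=O)/C=C/c1ccc(O)c(OC)c1)/C=C/c1ccc(O)c(OC)c1`: 97%
- compound 2, `COc1cc(/C=C/C(=O)/C=C(/C=C/c2ccc(OC(C)=O)c(OC)c2)NCC(C)C)ccc1OC(C)=O`: 96%
- compound 3, `COc1cc(/C=C/C(=O)CC(=O)/C=C/c2ccc(OC(C)=O)c(OC)c2)ccc1OC(C)=O`: 93%

All three numbers come from a functional assay on Caco-2 cells (Homo sapiens), read by fluorescence, tested at 1 uM; on this read-out higher numbers stand for a weaker effect at the one concentration tested and lower numbers for a stronger effect. In this assay compound 1 gives 97%, compound 2 gives 96% and compound 3 gives 93%. Compound 1 sits at the top of these three numbers, but its gaps to compound 2 and to compound 3 both lie within the usual scatter of repeated measurements, so the three cannot be told apart: each shows only a weak effect at the one concentration tested. Going by the values given here, no pair among them differs in just one place, so no single structural step has yet been paired with a change in the read-out.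

The new compound is compound 4, `COc1cc(/C=C/C(=O)/C=C(/C=C/c2ccc(O)c(OC)c2)NC2CCCCC2)ccc1O`. Against compound 1 it carries one change, (cyclohexyl in place of propyl on an amine nitrogen). The change touches only a carbon chain on the amine nitrogen; nothing polar is added or removed. With three measured compounds all resting near the weak end of the scale, there is no sign that this part of the molecule shifts the read-out. The step of a number 2 percentage points lower from compound 1 to compound 4 (within the scatter) is therefore expected to be none beyond the scatter. Compound 4 is expected to give 95%, with a range from 85% to 100%.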

Compound 4, a percentage reported as activity, at one concentration (the size of the read-out at that concentration, not a potency): 88%
Compound 4: the middle estimate sits 7 percentage points above what was measured, within the range that was stated.
By their numbers in this assay, from the lowest: compounds 4, 3, 2 and 1 (each within the scatter of the next).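

In this assay, going by these compounds alone, the pair of compounds gives the first direct reading at this position, with cyclohexyl in place of propyl on an amine nitrogen: the step is a number 9 percentage points lower from compound 1 to compound 4 (within the scatter) and so cannot be told from repeat-to-repeat noise. Within the data shown here, this shows that a propyl chain of 3 carbons can give way to a six-membered carbon ring of 6 carbons without a shift in the read-out that stands clear of the scatter, something the earlier compounds could not show, as none of them formed a pair differing in one place. No separate measurement bears on this step, and so nothing can be said about what lies behind the number.

Going by these compounds, it remains open whether a group of a different kind on this amine nitrogen, such as a phenyl ring, a carboxylic acid or a longer chain ending in an amine, would move the read-out beyond the scatter. A single pair at the one concentration tested also leaves open whether the swap would matter at other concentrations.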